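A Third Aryl Group on the Shared Core

The source may report more compounds than this note shows. Statements on the series, on what has been measured and on what is new or still open speak of the compounds shown alone.

Measured in a functional assay on PC-3 cells (Homo sapiens) for cytotoxicity, read by MTT assay, with a stated time of 72 h; a lower number here means a stronger inhibitor, a higher number a weaker inhibitor:
compound 1 `COc1cc2ncnc(Nc3ccc(F)c(Cl)c3)c2cc1NC(=O)N/N=C/c1ccc([N+](=O)[O-])cc1`: 32400 nM
compound 2 `COc1cc2ncnc(Nc3ccc(F)c(Cl)c3)c2cc1NC(=O)N/N=C/c1cc(OC)c(OC)c(OC)c1`: 36500 nM

For the measured compounds named here, compound 2 stands within the scatter of compound 1, the only other measured compound. Compound 3 `CCN(CC)c1ccc(/C=N/NC(=O)Nc2cc3c(Nc4ccc(F)c(Cl)c4)ncnc3cc2OC)c(O)c1` has not yet been measured. It carries 4-(diethylamino)-2-hydroxyphenyl in place of 3,4,5-trimethoxyphenyl on a carbon with a double bond to nitrogen. Going by the values given here, only one measured step bears on this change, the exchange at that same place, a 1.1-fold higher number from compound 1 to compound 2 (0.05 log units; within the scatter). Since that step stayed within the scatter, no step beyond the scatter is expected in this assay, in either direction. Among the compounds with values here, this is weak guidance, as no measured compound carries the incoming group. The estimated step is a 1.2-fold lower number from compound 2 to compound 3 (0.09 log units; within the scatter). The estimated value of compound 3 is 30000 nM, with an expected range from 10000 nM to 70000 nM.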

Compound 3, half-maximal inhibitory concentration: 34300 nM
Compound 3: the middle estimate sits 1.1-fold (0.06 log units) below what was measured; measured number inside the range.
By their numbers in this assay, from the lowest: compounds 1, 3 and 2 (each within the scatter of the next).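

In this assay, 4-(diethylamino)-2-hydroxyphenyl in place of 3,4,5-trimethoxyphenyl gives a 1.1-fold lower number from compound 2 to compound 3 (0.03 log units; within the scatter), and the same group in place of 4-nitrophenyl gives a 1.1-fold higher number from compound 1 to compound 3 (0.02 log units; within the scatter). The number therefore holds across three different aryl groups on the carbon with a double bond to nitrogen, even when a group with no hydrogen-bond donors gives way to one with a hydrogen-bond donor at an equal heavy-atom count. No measurement is available that would explain this flat result.

On these data alone, all three compounds carry an aryl group at this place, so it remains open whether a carboxylic acid, a morpholine or a simple alkyl chain there would produce a step beyond the scatter in this assay. The compounds shown also leave open how the number responds to any change away from this place, since the rest of the structure stays the same throughout.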